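Nitro in place of chloro on the shared core

The source may hold more compounds than are shown below. What is called first, only, known or untested is meant among the compounds shown, and "the series" means these compounds.

Of the compounds shown here, two have been measured so far. In a functional assay on MCF7 cells (Homo sapiens) for cytotoxicity, read by MTT assay, with a stated time of 96 h (on this read-out higher numbers stand for weaker inhibition and lower numbers for stronger inhibition), compound 1 (`COc1ccc(C2C(C#N)=C(N)Oc3cc(C)oc(=O)c32)cc1`) gives 57000 nM. In this assay compound 2 (`Cc1cc2c(c(=O)o1)C(c1ccc(Cl)cc1)C(C#N)=C(N)O2`) gives 32000 nM, which lies within the scatter of the value for compound 1, so the two cannot be ranked.

The next entry is compound 3 (`Cc1cc2c(c(=O)o1)C(c1ccc([N+](=O)[O-])cc1)C(C#N)=C(N)O2`), with nitro in place of chloro on an aromatic carbon compared with compound 2: nitro in place of chloro on an aromatic carbon. The exchange sits on an aromatic carbon of a six-membered aromatic ring of carbon only, para to a large group.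

Among the measured compounds shown here, one measured step bears on it: a 1.8-fold lower number from compound 1 to compound 2 (0.25 log units; within the scatter), with chloro in place of methoxy on an aromatic carbon. For the measured compounds named here, that single step stays within the scatter, and no nitro compound has been measured, so the basis is thin. No step beyond the scatter is therefore expected in this assay. The expected step is a 1.1-fold lower number from compound 2 to compound 3 (0.03 log units; within the scatter). For compound 3 the estimated value is 30000 nM, with an expected range of 10000 nM to 80000 nM.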

Compound 3, half-maximal inhibitory concentration: 42000 nM
The estimate for compound 3 lay 1.4-fold (0.15 log units) below the measured number, within the range that was stated.
By their numbers in this assay, from the lowest: compounds 2, 3 and 1 (each within the scatter of the next).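

In this assay, among the compounds shown here, the step of a 1.3-fold higher number from compound 2 to compound 3 (0.12 log units; within the scatter) for nitro in place of chloro and the step of a 1.4-fold lower number from compound 1 to compound 3 (0.13 log units; within the scatter) for nitro in place of methoxy both lie within the scatter, as did the one earlier step. The aromatic carbon para to a large group has now carried three different groups without any pair of compounds separating, so the absence of a readable difference no longer rests on a single pair. This holds even though nitro, with 3 heavy atoms and 2 hydrogen-bond acceptors, differs in those counts from chloro, with 1 heavy atom and 0 hydrogen-bond acceptors, and no measurement is available that would explain the result.

Still open, from the compounds shown here alone, is whether any group on this aromatic carbon can move the number beyond the scatter, for example a carboxylic acid, a hydroxyl or a longer alkyl chain. The three compounds also differ only at this one place, so they say nothing about how changes elsewhere on the shared core would read out in this assay.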